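Adding 1-methylpiperidin-4-yl to compound 1

A few compounds are considered here, and "the series" means these few. Any claim that something is new, unique, unknown or untested is made for them only; others in the source may bear on it.

- compound 1 `O=C(NCCCCc1ccccc1)n1cc(-c2ccc(F)cc2)oc1=O` gives 1.5 h
- compound 2 `O=C(NCCCCc1ccccc1)n1cc(-c2cccnc2)oc1=O` gives 1 h
- compound 3 `O=C(NCCCCc1ccccc1)n1cc(-c2cnccn2)oc1=O` gives 0.667 h

These three readings come from an ADME assay on a cell-free system (plasma, Mus musculus) for metabolic stability, read by LC-MS, tested at 2 uM (a higher number here means that the compound lasts longer, a lower number that the compound disappears faster), and the compounds differ only in the aromatic group on the shared core. Compound 1 stands at one end of the three numbers, with one neighbour inside the scatter and the other outside it. The nearest value lies at a 1.5-fold lower number from compound 1 to compound 2 (0.18 log units; within the scatter), and the furthest at a 2.2-fold lower number from compound 1 to compound 3 (0.35 log units; beyond the scatter). The remaining pair is separated by a 1.5-fold lower number from compound 2 to compound 3 (0.18 log units; within the scatter).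

Compound 4 `CN1CCC(c2cc(-c3cn(C(=O)NCCCCc4ccccc4)c(=O)o3)ccc2F)CC1` is still unmeasured and carries one change relative to compound 1: 1-methylpiperidin-4-yl in place of hydrogen on an aromatic carbon. Going by the values given here, no measured step adds a group to the ring carrying the fluoro group. Each one exchanges the whole aromatic group instead, so these steps bear on the change only loosely. The largest of them, a 2.2-fold lower number from compound 1 to compound 3 (0.35 log units; beyond the scatter), is modest and offers only a rough guide to size, and it gives no direction for an added group. No shift beyond the scatter is therefore expected in this assay, and the estimated change is a 1.3-fold lower number from compound 1 to compound 4 (0.10 log units; within the scatter). Compound 4 is expected at 1.2 h (estimated range 0.5 h to 3 h).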

Compound 4, half-life: > 2 h
Compound 4 was reported as a limit; the forecaster's own chance of this, stated with the estimate: 10%; middle value at least 1.6-fold (0.22 log units) from the limit.
By their numbers in this assay, from the lowest: compounds 3, 2 and 1 (each within the scatter of the next, the first and the last beyond it). At a limit, above all of these: compound 4.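

In this assay compound 4 is reported only as a limit, > 2 h, and it is the only such reading among the compounds shown: the limit of > 2 h in this assay, at which 1 of the 4 values shown sits. The step reads an at least 1.3-fold higher number from compound 1 to compound 4 (0.12 log units; that floor lies within the scatter), so its floor does not by itself establish a gain, but it does show that 1-methylpiperidin-4-yl in place of hydrogen, on an aromatic carbon ortho to a fluoro group and meta to a large group, brings no drop in half-life. The earlier steps shown here only exchanged the whole aromatic group, whereas this one shows that the ring carrying the fluoro group can take a substituent of this size while the compound lasts at least as long as compound 1 in this assay.

Going by these compounds alone, how far the half-life of compound 4 actually lies from that of compound 1 stays open, since a limit gives no size for the step. The compounds shown also leave open whether the same holds for a piperidin-4-yl without the methyl group, an open-chain amine or a carboxylic acid at this place, or for the same group added to the pyridin-3-yl ring of compound 2.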